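Thioamide chain variants on a phenyl pyridazinone core

This account rests on a few compounds, and the source may have more. Where it says the series, first, only, none or still open, it means among the compounds named here.

Measured so far:
compound 1 `N=C(S)CCCn1nc(-c2ccccc2)ccc1=O` — 31.9 mg/kg
compound 2 `Cc1ccc(=O)n(CCCC(=N)S)n1` — > 100 mg/kg

In a functional assay on the whole organism (stomach) with Rattus norvegicus as the target (on this read-out lower numbers stand for an effect already at smaller amounts and higher numbers for an effect only at larger amounts of compound), compound 1 gives 31.9 mg/kg, the only number shown. Compound 2 gives > 100 mg/kg, a limit of the assay (the limit of > 100 mg/kg in this assay, at which 1 of the 2 values shown sits). Within the data shown here, the one measured step, an at least 3.1-fold higher number from compound 1 to compound 2 (0.49 log units; beyond the scatter), concerns the aromatic substituent and does not touch the chain. Compound 3 `CN(C)C(=S)CCCCCn1nc(-c2ccccc2)ccc1=O` differs from compound 1 by a group of 7 heavy atoms (5 carbon, 1 nitrogen, 1 sulfur; no ring) in place of a group of 3 heavy atoms (1 carbon, 1 nitrogen, 1 sulfur; no ring), on a saturated chain carbon, three bonds along the chain from an aromatic nitrogen. Among the measured compounds shown here, no measured step bears on this change, so the expectation rests on compound 1 alone: a step of a 1.3-fold higher number from compound 1 to compound 3 (0.10 log units; within the scatter) is estimated, with wide uncertainty. Compound 3 is expected near 40 mg/kg, between 12 mg/kg and 130 mg/kg.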

Compound 3, dose for half-maximal effect: 100 mg/kg
Beside the measured number, compound 3's estimate is 2.5-fold (0.40 log units) below it; low and high end bracket the measured number.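

In this assay, the first change read at this position, a group of 7 heavy atoms in place of a group of 3 heavy atoms, gives a 3.1-fold higher number from compound 1 to compound 3 (0.50 log units; beyond the scatter), so the chain end does not tolerate every change. The entering group has 0 hydrogen-bond donors against 2 for the leaving group, and its carbon count differs as well, so this single step cannot separate the two. Compound 2 gives > 100 mg/kg, which is a limit of the assay: the limit of > 100 mg/kg in this assay, at which 1 of the 3 values shown sits.

Which part of the group of 7 heavy atoms carries the step remains open. Also open, from the compounds shown here alone, is how an amine or a carboxylic acid at the chain end would read on the shared core.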